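The compounds below may be only part of what the source reports. "The series", "measured", "known", "first", "only" and "open" are said of these compounds alone.

In a functional assay on HCT-116 cells (Homo sapiens) for antiproliferative activity, read by MTT assay, with a stated time of 24 h (a higher number here means a weaker inhibitor, a lower number a stronger inhibitor), three compounds have been measured so far. Compound 1 (`COc1ccc(C(=O)/C=C/c2cccc(F)c2)c2c1C=CC(C)(C)O2`) gives > 10000 nM as a limit of the assay and not a number. Compound 2 (`COc1ccc(C(=O)/C=C/c2ccc(N(c3ccccc3)c3ccccc3)cc2)c2c1C=CC(C)(C)O2`) gives > 10000 nM as a limit too. Among the compounds with values here, compound 3 (`COc1ccc(C(=O)/C=C/c2ccc(N3CCCC3)cc2)c2c1C=CC(C)(C)O2`) gives 8590 nM as the only actual number. Compound 1 therefore sits at the limit of > 10000 nM in this assay, at which 2 of the 3 values shown sit, and offers no exact starting value. Compound 4 (`COc1ccc(/C=C/C(=O)c2ccc(OC)c3c2OC(C)(C)C=C3)cn1`) changes one place of compound 1 (6-methoxypyridin-3-yl in place of 3-fluorophenyl on a double-bonded chain carbon bound to a double-bonded chain carbon): 6-methoxypyridin-3-yl in place of 3-fluorophenyl on a double-bonded chain carbon bound to a double-bonded chain carbon. Within the data shown here, no measured pair shows a single change of this kind. Among the measured compounds shown here, with compound 3 at 8590 nM as the only number, no step beyond the scatter is expected. The expected step is an at least 1.1-fold lower number from compound 1 to compound 4 (0.04 log units; that floor lies within the scatter) and no larger. For compound 4 the expected value in this assay is 9000 nM with an estimated range from 3000 nM to 20000 nM around it.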

Compound 4, half-maximal inhibitory concentration: > 10000 nM
Compound 4 gave a limit, no number; the forecaster's own chance of this, stated with the estimate: 55%; at least 1.1-fold (0.04 log units) between middle value and limit.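

Compound 1 and compound 4 both sit at a limit of this assay and not at a number, so no step between them can be read: the limit of > 10000 nM in this assay, at which 3 of the 4 values shown sit.

The compounds shown leave open how far 6-methoxypyridin-3-yl and 3-fluorophenyl differ in this place.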